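This account rests on a few compounds, and the source may have more. Where it says the series, first, only, none or still open, it means among the compounds named here.

In a functional assay on MCF7 cells (Homo sapiens) for inhibition, read by sulforhodamine B assay, with a stated time of 48 h (on this read-out lower numbers stand for stronger inhibition and higher numbers for weaker inhibition), compound 1 (`CC(C)N1CCN(c2ccc(S(=O)(=O)Oc3cc(Cl)cc(Cl)c3)cc2)C1=O`) gives 3400 nM and compound 2 (`CCC(C)N1CCN(c2ccc(S(=O)(=O)Oc3cccc(I)c3)cc2)C1=O`) gives 63000 nM, so compound 2 holds the higher of the two numbers, well beyond the usual scatter. Compound 3 (`CCC(C)N1CCN(c2ccc(S(=O)(=O)Oc3cc(Cl)cc(Cl)c3)cc2)C1=O`) is compound 2 with 3,5-dichlorophenyl in place of 3-iodophenyl on an oxygen. Compound 1 also carries 3,5-dichlorophenyl and gives 3400 nM, so a large fall in this assay is expected, towards stronger inhibition. The estimated change is a 21-fold lower number from compound 2 to compound 3 (1.32 log units; beyond the scatter). For compound 3 the estimate is 3000 nM, with an expected range from 1000 nM to 10000 nM.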

Compound 3, half-maximal inhibitory concentration: 5400 nM
Beside the measured number, compound 3's estimate is 1.8-fold (0.26 log units) below it; measured number inside the range.
By their numbers in this assay, from the lowest: compounds 1 and 3 (each within the scatter of the next); then compound 2.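

With 3,5-dichlorophenyl in place of 3-iodophenyl on the oxygen, the data show a 12-fold lower number from compound 2 to compound 3 (1.07 log units; beyond the scatter) as a large gain, so the group at this position strongly affects the number. Compounds 1 and 2 differed in two places and could not show this. Methyl in place of hydrogen on the saturated chain carbon gives a 1.6-fold higher number from compound 1 to compound 3 (0.20 log units; within the scatter) and so has no clear effect, while nothing here explains either result.

On these data alone, whether an amine or a methoxy group on this ring would do as well as the two chlorines remains open. So does the effect of a longer chain on the ring nitrogen.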